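One Chlorine, Two Places: Repeating a Small Step

The source may report more compounds than this note shows. Statements on the series, on what has been measured and on what is new or still open speak of the compounds shown alone.

Compound 1 `O=C(NCc1cn[nH]c1)Nc1ccc(S(=O)(=O)c2ccccc2)cc1` is the starting point, and in an assay on isolated protein for activation of Nicotinamide phosphoribosyltransferase (Homo sapiens) (a higher number here means that more compound is needed for the effect, a lower number that less compound is needed), compound 1 gives 28 nM. Compound 2 `O=C(NCc1cn[nH]c1)Nc1ccc(S(=O)(=O)c2ccc(Cl)cc2)cc1` carries a single change relative to compound 1, namely (chloro in place of hydrogen on an aromatic carbon), and in this assay compound 2 gives 23 nM. The step between them is a 1.2-fold lower number from compound 1 to compound 2 (0.09 log units; within the scatter), so these two values cannot be told apart. Compound 3 `O=C(NCc1ccncc1)Nc1ccc(S(=O)(=O)c2ccccc2)cc1` has a different core from compound 1, the difference being (pyridin-4-yl in place of 1H-pyrazol-4-yl on a saturated chain carbon bound to an amide-type nitrogen), and in this assay compound 3 gives 85 nM. The step here is a 3.0-fold higher number from compound 1 to compound 3 (0.48 log units; beyond the scatter), a change that does exceed the scatter.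

Compound 4 `O=C(NCc1ccncc1)Nc1ccc(S(=O)(=O)c2cccc(Cl)c2)cc1` has not yet been measured. It differs from compound 3 by chloro in place of hydrogen on an aromatic carbon. Going by the values given here, this is the same kind of change as the one from compound 1 to compound 2, but not the same change: in compound 2 the chloro sits para to a large group, whereas in compound 4 it sits meta to a large group. The expected step is a 1.1-fold lower number from compound 3 to compound 4 (0.05 log units; within the scatter), which rests on a 1.2-fold lower number from compound 1 to compound 2 (0.09 log units; within the scatter) having stayed within the scatter and on the new change being of the same kind, though at a different place on the ring. In this assay compound 4 is therefore estimated at 75 nM, with a likely range from 35 nM to 160 nM.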

Compound 4, half-maximal effective concentration: 69 nM
Compound 4: middle estimate off by 1.1-fold (0.04 log units), on the high side; low and high end bracket the measured number.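

In this assay, adding the chlorine to the core that carries pyridin-4-yl gives a 1.2-fold lower number from compound 3 to compound 4 (0.09 log units; within the scatter), a step too small to tell apart from the ordinary variation between repeated measurements. Set beside the same kind of change on the core that carries 1H-pyrazol-4-yl, the two small steps agree: the same change on two cores in this assay, a 1.2-fold lower number (0.09 log units; within the scatter) from compound 1 to compound 2 and a 1.2-fold lower number (0.09 log units; within the scatter) from compound 3 to compound 4, 1.0-fold (0.01 log units) apart, within the scatter of two such steps So on both cores shown, a chlorine on the phenyl ring leaves the number where it was, but this is agreement between two steps that are each within the scatter, with the chlorine at a different place on the ring in compound 2 and in compound 4, so it does not show that a change with a clear effect would carry over from one core to the other, or that the same would hold on any further core.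

The compounds shown leave open whether a chlorine at one and the same place on the ring would read alike on both cores. They also leave open whether a different group on that ring, such as a carboxylic acid or an amine, would give a step beyond the scatter, and whether such a step would then repeat from one core to the other.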